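Removing the cyclopropylamino group from compound 1

The compounds below may be only part of what the source reports. "The series", "measured", "known", "first", "only" and "open" are said of these compounds alone.

compound 1 `COc1c(NC(=O)c2cc3cccc(NC(=O)c4ccc(NC5CC5)nc4)c3s2)cc(C(C)(C)C)cc1NS(C)(=O)=O`: 51% in an in vivo ADME assay on the whole organism (strain Sprague-Dawley) for pharmacokinetics, with Rattus norvegicus as the target, at a dose of 10 mg/kg by the oral route; on this read-out higher numbers stand for higher oral bioavailability and lower numbers for lower oral bioavailability
compound 2 `COc1c(NC(=O)c2cc3cccc(NC(=O)c4cccnc4)c3n2C)cc(C(C)(C)C)cc1NS(C)(=O)=O`: 90%

Compound 1 stands lowest of the two numbers in this assay; its nearest neighbour, compound 2, lies higher by a margin beyond the scatter. Compound 3 `COc1c(NC(=O)c2cc3cccc(NC(=O)c4cccnc4)c3s2)cc(C(C)(C)C)cc1NS(C)(=O)=O` differs from compound 1 by hydrogen in place of cyclopropylamino on an aromatic carbon. Going by the values given here, no step between measured compounds covers this change, so its effect in this assay is not yet known. Compound 2, which also carries the plain (pyridin-3-yl)carbonyl but on a different core, gives 90%. A moderate rise is expected, a number 14 percentage points higher from compound 1 to compound 3 (beyond the scatter). Compound 3 is estimated at 65%, within 40% to 90%.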

Compound 3, oral bioavailability: 57%
The estimate for compound 3 lay 8 percentage points above the measured number, within the range that was stated.
By their numbers in this assay, from the lowest: compounds 1 and 3 (each within the scatter of the next); then compound 2.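

With hydrogen in place of cyclopropylamino, the step in this assay reads a number 6 percentage points higher from compound 1 to compound 3 (within the scatter), so the two compounds are not separated. On the aromatic carbon next to the ring nitrogen, the whole group, including its three-membered ring, can go without a difference this read-out can resolve. Nothing available explains this result.

As far as these compounds go, whether a simple amine, a methoxy group or a fluorine atom on this carbon would also leave the read-out within the scatter stays open. So does whether the same change behaves alike on a different core.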